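A Second Fluoro on Compound 2

This account rests on a few compounds, and the source may have more. Where it says the series, first, only, none or still open, it means among the compounds named here.

Measured in a functional assay on SEM cells (Homo sapiens) for cytotoxicity, with a stated time of 72 h; a higher number here means that more compound is needed for the effect, a lower number that less compound is needed:
- Compound 1 `C=C[C@@](C)(/C=C/c1ccc(OS(=O)(=O)C(F)(F)F)cc1)CCC=C(C)C`: > 36600 nM, a limit
- Compound 2 `C=C[C@@](C)(/C=C/c1ccc(Nc2ccc(F)cc2)cc1)CCC=C(C)C`: > 36600 nM, a limit

Compound 2 stands at a limit with > 36600 nM, so it offers no number to start from. Both measured compounds rest on (the limit of > 36600 nM in this assay, at which 2 of the 2 values shown sit). For the measured compounds named here, the one measured step is a step that the two limits leave unreadable from compound 1 to compound 2, with (4-fluorophenyl)amino in place of ((trifluoromethyl)sulfonyl)oxy on an aromatic carbon.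

Compound 3 `C=C[C@@](C)(/C=C/c1ccc(Nc2ccc(F)c(F)c2)cc1)CCC=C(C)C` follows from compound 2 by a single change: fluoro in place of hydrogen on an aromatic carbon. This is fluoro in place of hydrogen on an aromatic carbon, ortho to a fluoro group, which turns 4-fluorophenyl into 3,4-difluorophenyl.

Going by the values given here, with a step that the two limits leave unreadable from compound 1 to compound 2 as the only guide, no size can be carried over, and no step beyond the scatter is expected in this assay. The expected step is a step that the limit leaves unreadable from compound 2 to compound 3, and another limit is the likeliest report. Compound 3 is estimated at 40000 nM, with an expected range from 18000 nM to 70000 nM.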

Compound 3, half-maximal effective concentration: > 36600 nM
Compound 3 was reported as a limit; the forecaster's own chance of this, stated with the estimate: 80%; the middle value lies beyond the limit too.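

Compound 1, compound 2 and compound 3 are all reported only as limits in this assay, so no step among them can be read: the limit of > 36600 nM in this assay, at which 3 of the 3 values shown sit.

The compounds shown leave open whether any change to the shared core gives a measurable value in this assay.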